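Methoxy added to the indole core of a vinyl sulfone

This account rests on a few compounds, and the source may have more. Where it says the series, first, only, none or still open, it means among the compounds named here.

Compound 1: `COc1ccc(-c2[nH]c3ccccc3c2/C=C(\C#N)S(=O)(=O)c2ccccc2)cc1` with 2100 nM
Compound 2: `COc1ccc2[nH]c(-c3ccccc3)c(C=C(C#N)C#N)c2c1` with 2600 nM

Of the compounds shown here, two have been measured in a functional assay on RPMI-8226 cells (Homo sapiens) for inhibition, read by sulforhodamine B assay, with a stated time of 48 h; a lower number here means a stronger inhibitor of growth, a higher number a weaker inhibitor of growth. Compound 1 gives 2100 nM, the lower of the two numbers, while compound 2 gives 2600 nM; the gap between them lies within the usual scatter, so the two values cannot be ordered. Among the measured compounds shown here, nothing else about the series is known, and no pair of measured compounds differs in one place only.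

Compound 3, `COc1ccc(-c2[nH]c3ccc(OC)cc3c2/C=C(\C#N)S(=O)(=O)c2ccccc2)cc1`, is the next compound to be tested. It differs from compound 1 in one place: methoxy in place of hydrogen on an aromatic carbon. For the measured compounds named here, no measured pair shows the effect of this change, so its size is not known from the data at hand. With compound 1 at 2100 nM and compound 2 at 2600 nM standing close together, a step in this assay of modest size is expected, and the direction is open; a result within the scatter of compound 1 is the most likely outcome.

Compound 3 is therefore expected to give 1500 nM, with a range of 500 nM to 5000 nM, which means an expected step of a 1.4-fold lower number from compound 1 to compound 3 (0.15 log units; within the scatter).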

Compound 3, concentration for 50% growth inhibition: 1300 nM
Estimate against measurement, compound 3: 1.2-fold (0.06 log units) above; measured number inside the range.
By their numbers in this assay, from the lowest: compounds 3, 1 and 2 (each within the scatter of the next).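

In this assay, methoxy in place of hydrogen on an aromatic carbon of the shared core, at the place that is meta to a fused ring and para to a fused ring, gives a 1.6-fold lower number from compound 1 to compound 3 (0.21 log units; within the scatter), a step within the scatter, so neither a gain nor a loss can be read from it. Among the compounds shown here, this is the first pair that differs in one place only, and it shows that this aromatic carbon can carry methoxy, with its 2 heavy atoms and 1 hydrogen-bond acceptor, without a change in growth inhibition beyond the scatter. Nothing at hand offers an explanation for this result.

The compounds shown do not tell whether this position would respond the same way to a different group, such as an amine, a carboxylic acid, a chlorine atom or a longer chain such as butoxy. They also leave open whether the same methoxy would give a similar result on another aromatic carbon of the core of compound 1, since this single pair speaks for one position and one group alone.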